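From ethyl to vinyl on a triple-bonded carbon

The source may report more compounds than this note shows. Statements on the series, on what has been measured and on what is new or still open speak of the compounds shown alone.

Measured in a functional assay on MIA PaCa-2 cells (Homo sapiens) for antiproliferative activity; on this read-out lower numbers stand for an effect already at smaller amounts and higher numbers for an effect only at larger amounts of compound:
- compound 1 `C#CCNC(=O)c1cccc2c1cc(C)n2-c1nc2c(c(NCc3ccccc3)n1)CCCC2`: 470 nM
- compound 2 `C#CCCNC(=O)c1cccc2c1cc(C)n2-c1nc2c(c(NCc3ccccc3)n1)CCCC2`: 1410 nM
- compound 3 `CCC#CC(=O)Nc1cccc2c1cc(C)n2-c1nc2c(c(NCc3ccccc3)n1)CCCC2`: 463 nM

Compound 3 shares the low end of these numbers with compound 1, as shown by a 1.0-fold lower number from compound 1 to compound 3 (0.01 log units; within the scatter). Compound 2 stands apart, as shown by a 3.0-fold lower number from compound 2 to compound 3 (0.48 log units; beyond the scatter).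

The next compound, compound 4 `C=CC#CC(=O)Nc1cccc2c1cc(C)n2-c1nc2c(c(NCc3ccccc3)n1)CCCC2`, has vinyl in place of ethyl on a triple-bonded carbon. Among the measured compounds shown here, no measured step makes this exchange, so the evidence is indirect. The larger change in a 1.0-fold lower number from compound 1 to compound 3 (0.01 log units; within the scatter) left the number within the scatter, while a 3.0-fold higher number from compound 1 to compound 2 (0.48 log units; beyond the scatter) shows that a change in the alkyne-bearing chain can produce a modest shift. With so few compounds, neither the direction nor the size of a shift in this assay can be fixed, and no step beyond the scatter is expected. The estimated result is a 1.1-fold lower number from compound 3 to compound 4 (0.04 log units; within the scatter). For compound 4, the expected value is 420 nM, with an estimated range of 160 nM to 1200 nM.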

Compound 4, half-maximal effective concentration: 892 nM
Compound 4: the middle estimate sits 2.1-fold (0.33 log units) below what was measured, and the stated range covers the measured number.
By their numbers in this assay, from the lowest: compounds 3, 1, 4 and 2 (each within the scatter of the next, the first and the last beyond it).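

In this assay, vinyl in place of ethyl on a triple-bonded carbon gives a step within the scatter (a 1.9-fold higher number from compound 3 to compound 4 (0.28 log units; within the scatter)), so the double bond outside aromatic rings brings no readable change at this position. Compound 4 also cannot be separated from the other two compounds (a 1.9-fold higher number from compound 1 to compound 4 (0.28 log units; within the scatter); a 1.6-fold lower number from compound 2 to compound 4 (0.20 log units; within the scatter)), even though compound 2 lies beyond the scatter of compound 1 and compound 3. No measurement available here bears on this result.

Still open, going by these compounds, is whether a longer chain or a dimethylamine group on the triple-bonded carbon would give a step beyond the scatter. With only ethyl and vinyl at this place, the compounds shown set no trend for this position.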